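Methoxy in Place of Methyl: A Forecast from One Step

A few compounds are considered here, and "the series" means these few. Any claim that something is new, unique, unknown or untested is made for them only; others in the source may bear on it.

Among the compounds with values here, only two compounds have been measured so far. In a functional assay on A549 cells (Homo sapiens) for antiproliferative activity, read by MTT assay, with a stated time of 48 h (on this read-out lower numbers stand for stronger inhibition and higher numbers for weaker inhibition), compound 1 `O=C(/C=C/c1ccc(F)cc1)Nc1nnc(-c2ccc(Br)cc2)s1` gives 2.83 ug/mL and compound 2 `Cc1ccc(/C=C/C(=O)Nc2nnc(-c3ccc(Br)cc3)s2)cc1` gives 1.51 ug/mL. These two numbers lie within the usual scatter of each other, so compound 2 cannot yet be told apart from compound 1.

The next compound, compound 3 `COc1ccc(/C=C/C(=O)Nc2nnc(-c3ccc(Br)cc3)s2)cc1`, keeps the shared core and changes one group of compound 2: methoxy in place of methyl on an aromatic carbon, para to a large group (methoxy in place of methyl on an aromatic carbon). Just one measured step bears on this change, and it too is a swap of a small group on an aromatic carbon: a 1.9-fold lower number from compound 1 to compound 2 (0.27 log units; within the scatter). A single step is thin evidence, and it says nothing directly about methoxy. On that basis, no step beyond the scatter is expected in this assay, and no direction can be favoured with confidence. The estimated step is a 1.3-fold higher number from compound 2 to compound 3 (0.12 log units; within the scatter). For compound 3 the expected value is 2 ug/mL, with an estimated range from 0.9 ug/mL to 4.5 ug/mL.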

Compound 3, half-maximal inhibitory concentration: 1.04 ug/mL
Estimate against measurement, compound 3: 1.9-fold (0.28 log units) above; the measured number falls inside the stated range.
By their numbers in this assay, from the lowest: compounds 3, 2 and 1 (each within the scatter of the next, the first and the last beyond it).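

In this assay, putting methoxy in place of methyl gives a 1.5-fold lower number from compound 2 to compound 3 (0.16 log units; within the scatter), so the extra oxygen, which brings one hydrogen-bond acceptor, does not separate these two compounds at this position, para to a large group. Within the data shown here, the comparison with fluoro adds something the first two compounds could not show, since a 2.7-fold lower number from compound 1 to compound 3 (0.43 log units; beyond the scatter) is the first step in this small set to pass beyond the scatter, though only modestly: the choice of group at this position can shift the number, with methoxy and fluoro now told apart and methyl still within the scatter of both. No measurement offered here speaks to what lies behind these differences.

Among these compounds, with only three small groups compared at one position, it remains open how an amine, a hydroxyl or a longer ether such as ethoxy would fall there, and whether any of them would move the number well beyond the scatter. The bromo group is also the same in all three compounds, so these numbers say nothing about what replacing it with chloro or another group would do.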